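The source may report more compounds than this note shows. Statements on the series, on what has been measured and on what is new or still open speak of the compounds shown alone.

In a functional assay on MDA-MB-231 cells (Homo sapiens) for inhibition, read by CCK-8 assay, with a stated time of 48 h (a lower number here means a stronger inhibitor of growth, a higher number a weaker inhibitor of growth), three compounds with a shared core have been measured, and they differ in the group on a nitrogen on an aromatic ring. Compound 1 `Cc1ccccc1Nc1nc(NC2CCCCC2)ncc1Cl`, with cyclohexyl, gives > 100000 nM, which is a limit of the assay and not a number. Compound 2 `Cc1ccccc1Nc1nc(Nc2ccccc2)ncc1Cl`, with phenyl, gives > 100000 nM, also a limit. Compound 3 `Cc1ccccc1Nc1nc(NCc2ccco2)ncc1Cl`, with (furan-2-yl)methyl, gives > 100000 nM, again a limit, so it has no exact position in the series. The three results share one ceiling: the limit of > 100000 nM in this assay, at which 3 of the 3 values shown sit.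

Compound 4 `Cc1ccccc1Nc1nc(Nc2ccccn2)ncc1Cl` has not yet been measured and carries pyridin-2-yl in place of (furan-2-yl)methyl on a nitrogen on an aromatic ring. For the measured compounds named here, three measured steps bear on this change: a step that the two limits leave unreadable from compound 1 to compound 2, a step that the two limits leave unreadable from compound 1 to compound 3 and a step that the two limits leave unreadable from compound 2 to compound 3. None of them offers a size to carry over, so no gain in this assay is expected and no direction can be named. The expected change is a number no higher from compound 3 to compound 4 (the limit leaves the size open), which is no clear step beyond the scatter. For compound 4 the estimated value is 100000 nM, with an expected range from 30000 nM to 300000 nM.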

Compound 4, concentration for 50% growth inhibition: 11200 nM
Compound 4: middle estimate off by 8.9-fold (0.95 log units), on the high side, and the stated range ends above it.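

In this assay, for the compounds shown here, pyridin-2-yl is the first group on this nitrogen to give a readable value, and replacing (furan-2-yl)methyl with it gives an at least 8.9-fold lower number from compound 3 to compound 4 (0.95 log units; beyond the scatter). The same group gives an at least 8.9-fold lower number from compound 2 to compound 4 (0.95 log units; beyond the scatter), so an aromatic six-membered ring with a nitrogen in it differs clearly from the all-carbon phenyl ring, and it gives an at least 8.9-fold lower number from compound 1 to compound 4 (0.95 log units; beyond the scatter) when it replaces cyclohexyl. These steps show that the group at this place can move the number beyond the scatter, but each is only a minimum, and the steps among the three earlier compounds cannot be read, because those compounds all sit at one ceiling: the limit of > 100000 nM in this assay, at which 3 of the 4 values shown sit.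

The compounds shown leave open whether other nitrogen-containing rings, such as pyrimidin-2-yl, would match pyridin-2-yl. They also leave open how a methyl, methoxy or amine group on the pyridine ring would change the number.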